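Swapping a cyclohexylamino for a second pyridinyloxy group

A few compounds are considered here, and "the series" means these few. Any claim that something is new, unique, unknown or untested is made for them only; others in the source may bear on it.

Compound 1 `N#Cc1ccc(Oc2cccnc2)cc1NC1CCCCC1` gives 33% in an assay on isolated protein for inhibition of Aromatase (Homo sapiens), read by fluorescence, tested at 1 uM (on this read-out higher numbers stand for more inhibition at the one concentration tested (going by the name of the read-out) and lower numbers for less inhibition), the lowest of the two plain numbers recorded. Compound 2 `N#Cc1ccc(-n2ccc3ccncc32)cc1Oc1ccccc1` gives 97%, a figure higher than that of compound 1 by a margin well beyond the scatter. Compound 3 `Cc1cc(-n2ccc3ccncc32)ccc1C#N` is recorded only as > 99%, which is a limit of the assay rather than a number (the limit of > 99% in this assay, at which 1 of the 3 values shown sits). The step of a number at least 2 percentage points higher from compound 2 to compound 3 (that floor lies within the scatter) puts methyl in place of phenoxy, and its floor lies within the scatter.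

Compound 4 `N#Cc1ccc(Oc2cccnc2)cc1Oc1cccnc1` arises from compound 1 by (pyridin-3-yl)oxy in place of cyclohexylamino on an aromatic carbon. Within the data shown here, no measured step exchanges these same two groups, so the step from compound 2 to compound 3 bears on it only loosely, showing that changes at an aromatic carbon of this shared core can leave inhibition high. With compound 1 sitting far below compound 2, room for a rise is large. Compound 4 is expected to reach 75%, within 40% to 95%, an estimated step of a number 42 percentage points higher from compound 1 to compound 4 (beyond the scatter) upward.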

Compound 4, a percentage reported as inhibition, at one concentration (the size of the read-out at that concentration, not a potency): 81%
For compound 4 the middle estimate is 6 percentage points below the measured one; low and high end bracket the measured number.
By their numbers in this assay, from the lowest: compound 1; then compound 4; then compound 2. At a limit, above all of these: compound 3.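

In this assay, putting (pyridin-3-yl)oxy in place of cyclohexylamino on the aromatic carbon ortho to a cyano group gives a number 48 percentage points higher from compound 1 to compound 4 (beyond the scatter). The rest of the molecule stays the same, so this is the first direct sign among these compounds that the group at this one place matters to the read-out. Compound 3 alone is recorded as a limit, while compound 4 keeps a plain number that can still be compared: the limit of > 99% in this assay, at which 1 of the 4 values shown sits.

The exchange swaps a non-aromatic carbon ring for an aromatic ring with a hetero atom, and it also changes the linking atom, so these compounds cannot say which difference counts. As far as these compounds go, how cyclohexyloxy or anilino would read at this place on the shared core remains open, and either would separate the linking atom from the ring.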